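This account rests on a few compounds, and the source may have more. Where it says the series, first, only, none or still open, it means among the compounds named here.

Compound 1 `O=C1CS/C(=N/Nc2nncc3ccccc23)N1c1ccccc1`: 3 nM
Compound 2 `Cc1cc(C)nc(NS(=O)(=O)c2ccc(Nc3nncc4ccccc34)cc2)n1`: 9.5 nM

Both compounds were tested in a functional assay on HL-60 cells (Homo sapiens) for antiproliferative activity, read by sulforhodamine B assay, with a stated time of 72 h; on this read-out higher numbers stand for weaker inhibition and lower numbers for stronger inhibition. Compound 2, at 9.5 nM, has the higher of the two numbers and so is the weaker inhibitor here. Compound 1, at 3 nM, lies lower by more than the usual scatter. The two differ in more than one place, so this gap cannot be tied to any single group.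

Compound 3 `O=S(=O)(Nc1ncccn1)c1ccc(Nc2nncc3ccccc23)cc1` has not yet been measured. It differs from compound 2 in one place: pyrimidin-2-yl in place of 4,6-dimethylpyrimidin-2-yl on a sulfonamide nitrogen. In words, this is pyrimidin-2-yl in place of 4,6-dimethylpyrimidin-2-yl on a sulfonamide nitrogen. Going by the values given here, no measured pair shows the effect of this change, so the expectation stays close to compound 2 at 9.5 nM, with no step beyond the scatter expected in this assay. The expected step is a 1.3-fold higher number from compound 2 to compound 3 (0.10 log units; within the scatter). The estimate for compound 3 is 12 nM, with an expected range from 4 nM to 40 nM.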

Compound 3, half-maximal inhibitory concentration: 67 nM
The estimate for compound 3 lay 5.6-fold (0.75 log units) below the measured number; the whole stated range lies below it.
By their numbers in this assay, from the lowest: compound 1; then compound 2; then compound 3.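

In this assay, the change from 4,6-dimethylpyrimidin-2-yl to pyrimidin-2-yl on the sulfonamide nitrogen gives a 7.1-fold higher number from compound 2 to compound 3 (0.85 log units; beyond the scatter), so this position is sensitive to a small edit. The ring type and the counted hydrogen-bond donors and acceptors stay the same, so the two groups differ only in the two methyl groups, and the step goes with their loss in this single pair. Nothing in the data given explains the size of this step.

From the compounds shown here alone, it remains open whether 4-methylpyrimidin-2-yl, with one methyl group, would fall nearer compound 2 or compound 3. Going by these compounds, it is also open whether larger groups in place of the methyl groups, such as ethyl or methoxy, would give lower numbers than compound 2 or higher ones.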